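A Chloro for Hydroxy Swap on the Phenyl Ring

The source may hold more compounds than are shown below. What is called first, only, known or untested is meant among the compounds shown, and "the series" means these compounds.

Values from a functional assay on the whole organism (strain albino) with Mus musculus as the target, with a stated time of 0.5 h (on this read-out higher numbers stand for an effect only at larger amounts of compound and lower numbers for an effect already at smaller amounts), are these.
Compound 1 `CC(=O)N1N=C(Nc2nc3ccccc3s2)CC1c1ccc(Cl)cc1` gives "not determined" (no result reported)
Compound 2 `CC(=O)N1N=C(Nc2nc3ccc([N+](=O)[O-])cc3s2)CC1c1ccc(Cl)cc1` gives 138 umol/kg
Compound 3 `CC(=O)N1N=C(Nc2nc3ccc(Cl)cc3s2)CC1c1ccc(O)cc1` gives 107 umol/kg

Among the measured compounds shown here, only two of the three compounds carry a number, since no result was reported for compound 1. Compound 3 (107 umol/kg) lies within the usual scatter of compound 2 (138 umol/kg), so the data set no order between them.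

The account now turns to compound 4 `CC(=O)N1N=C(Nc2nc3ccc(Cl)cc3s2)CC1c1ccc(Cl)cc1`, which has not yet been measured. It differs from compound 3 in one place, by chloro in place of hydroxy on an aromatic carbon in the count of the exchange. In words, this is chloro in place of hydroxy on an aromatic carbon, para to a large group, so that 4-hydroxyphenyl becomes 4-chlorophenyl.

For the measured compounds named here, no measured pair isolates this exchange, so its size has to be judged with caution. Compound 2 already carries the 4-chlorophenyl group and gives 138 umol/kg in this assay while also differing from compound 3 in a second place, so it offers only loose guidance. The expected size of a 1.1-fold lower number from compound 3 to compound 4 (0.05 log units; within the scatter) is nothing beyond the scatter, with no firm direction. For compound 4 the estimated value is 95 umol/kg with an expected range of 38 umol/kg to 235 umol/kg in this read-out.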

Compound 4, dose for half-maximal effect: 81.5 umol/kg
Beside the measured number, compound 4's estimate is 1.2-fold (0.07 log units) above it; the range from low to high includes it.
By their numbers in this assay, from the lowest: compounds 4, 3 and 2 (each within the scatter of the next).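

In this assay, the exchange of chloro for hydroxy at this place on the phenyl ring (a 1.3-fold lower number from compound 3 to compound 4 (0.12 log units; within the scatter)) stays within the scatter, so the 4-hydroxyphenyl and 4-chlorophenyl groups cannot be told apart here, although the group that leaves counts one hydrogen-bond donor and one acceptor and the group that enters counts neither. Compound 4 also supplies a second comparison in one place, chloro in place of nitro on an aromatic carbon (a 1.7-fold lower number from compound 2 to compound 4 (0.23 log units; within the scatter)), which also stays within the scatter, whereas compound 2 and compound 3 differ in two places and could not separate either exchange. Nothing at hand explains why neither exchange moves the number beyond the scatter.

Going by these compounds, compound 1 has no number ("not determined" (no result reported)), so the reading for the shared core without chloro or nitro on that ring stays unknown. On these data alone, how an amine, a methoxy group or a longer chain would read at this place on the phenyl ring also stays open, as does whether any exchange here can reach beyond the scatter.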